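Dropping the other methoxy from compound 1

The source may hold more compounds than are shown below. What is called first, only, known or untested is meant among the compounds shown, and "the series" means these compounds.

Measured compounds:
compound 1 `COc1nn2cc(-c3cc4c(OC)ccc(OC)c4o3)nc2s1` gives 10000 nM in an assay on a cell-free system (plasma) for antagonist activity at proteinase-activated receptor 4 (Homo sapiens), with a stated time of 5 min, in the presence of a further agent that is not named here; a higher number here means a weaker inhibitor, a lower number a stronger inhibitor
compound 2 `COc1nn2cc(-c3cc4c(OC)cccc4o3)nc2s1` gives 1300 nM in this assay
compound 3 `COc1cc(OCc2cccc(Oc3ccccc3)c2)c2cc(-c3cn4nc(OC)sc4n3)oc2c1` gives 390 nM in this assay

Compound 1 stands with the highest number of the three in this assay. Its nearest neighbour is compound 2, and the gap between the two, a 7.7-fold lower number from compound 1 to compound 2 (0.89 log units; beyond the scatter), lies beyond the scatter. For the measured compounds named here, the gap to compound 3 is wider still; the two values show it, though no single-change step connects them.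

Compound 4 `COc1nn2cc(-c3cc4cccc(OC)c4o3)nc2s1` is not yet measured. It differs from compound 1 by hydrogen in place of methoxy on an aromatic carbon. Going by the values given here, the only measured step that bears on this change is the removal of the other methoxy, a 7.7-fold lower number from compound 1 to compound 2 (0.89 log units; beyond the scatter), which gave a lower number beyond the scatter. Nothing on record separates the two methoxy groups from each other, so the same direction is expected here, with the size left uncertain and held a little short of that precedent.

For compound 4 the number in this assay is therefore estimated at 2500 nM, within 800 nM to 8000 nM. The expected step, a 4.0-fold lower number from compound 1 to compound 4 (0.60 log units; beyond the scatter), is a modest lowering.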

Compound 4, half-maximal inhibitory concentration: 3500 nM
For compound 4 the middle estimate is 1.4-fold (0.15 log units) below the measured one; the range from low to high includes it.
By their numbers in this assay, from the lowest: compound 3; then compound 2; then compound 4; then compound 1.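

In this assay the methoxy para to a methoxy group on the aromatic ring of compound 1 can also be replaced by hydrogen without a rise in the number, with a 2.9-fold lower number from compound 1 to compound 4 (0.46 log units; beyond the scatter). Read beside a 7.7-fold lower number from compound 1 to compound 2 (0.89 log units; beyond the scatter), this shows that removing either methoxy singly from compound 1 moves the number in the same direction, beyond the scatter each time, so the earlier lowering was not confined to one methoxy of the pair. No measurement on hand explains why either removal lowers the number.

The compounds shown leave open what happens when both methoxy groups are replaced by hydrogen at once, and whether the two steps would add up in such a compound. They also leave open whether a chlorine atom, a hydroxyl group or a longer alkoxy chain at this position would give a number above or below that of hydrogen, which would show whether the lowering depends on hydrogen itself or only on the loss of methoxy.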